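This account rests on a few compounds, and the source may have more. Where it says the series, first, only, none or still open, it means among the compounds named here.

In an ADME assay on HEK293 cells (Homo sapiens) for cytotoxicity, read by reporter gene assay and resazurin assay, with a stated time of 48 h (on this read-out higher numbers stand for lower toxicity in this test and lower numbers for higher toxicity in this test), compound 1 `COc1ccccc1C(=O)Nc1ccc(Sc2nc3ccccc3s2)cc1` gives > 100000 nM, which is a limit of the assay and not a number. Compound 2 `COc1ccccc1C(=O)Nc1ccc(Sc2nc3ccccc3s2)c(Cl)c1` gives > 100000 nM, also a limit. Compound 3 `COc1c(Br)cc(Br)cc1C(=O)Nc1ccc(Sc2nc3ccccc3s2)cc1` gives > 100000 nM, again a limit. Going by the values given here, compound 1 therefore has no exact position on this scale, and the series so far is defined by the limit of > 100000 nM in this assay, at which 3 of the 3 values shown sit.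

Compound 4 `O=C(Nc1ccc(Sc2nc3ccccc3s2)cc1)c1cccc(Br)c1` is the next to be considered, and its change from compound 1 is 3-bromophenyl in place of 2-methoxyphenyl on a carbonyl carbon. Among the compounds with values here, the only measured step between compounds differing in one place is a step that the two limits leave unreadable from compound 1 to compound 2, which replaces hydrogen with chloro on an aromatic carbon. It gives no readable size and is a different change from 3-bromophenyl in place of 2-methoxyphenyl. The expectation for this assay therefore rests on (the limit of > 100000 nM in this assay, at which 3 of the 3 values shown sit), and no step beyond the scatter is expected in either direction. The expected step is a number no higher from compound 1 to compound 4 (the limit leaves the size open). For compound 4 the estimated value is 100000 nM, with an expected range from 40000 nM to 200000 nM.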

Compound 4, half-maximal cytotoxic concentration: 74000 nM
Compound 4: the middle estimate sits 1.4-fold (0.13 log units) above what was measured, within the range that was stated.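

Going by these compounds alone, at this carbonyl carbon, 3-bromophenyl in place of 2-methoxyphenyl gives the first reading in this assay that is a number rather than a limit, with compound 4 at 74000 nM. The change gives an at least 1.3-fold lower number from compound 1 to compound 4 (0.13 log units; that floor lies within the scatter), so the compounds shown establish no drop beyond the scatter, and the true size of the step remains open. Compound 4 is the only compound shown with an exact position, and the rest of the series stays at the assay limit: the limit of > 100000 nM in this assay, at which 3 of the 4 values shown sit.

The compounds shown leave open whether the reading of compound 4 goes with the loss of 2-methoxyphenyl or the arrival of 3-bromophenyl. On these data alone, it also remains open how an unsubstituted phenyl, or a phenyl carrying an amine or a carboxylic acid, would read on this carbonyl carbon.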